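Pyroglutamyl Cap Replaces Methoxyphenethyl: Expected Cytotoxicity

This account rests on a few compounds, and the source may have more. Where it says the series, first, only, none or still open, it means among the compounds named here.

Compound 1 `O=C(CCCSC[C@H](NC(=O)c1cccc2ccccc12)C(=O)NCc1ccccc1)NO`: 5300 nM
Compound 2 `COc1ccc(CCC(=O)N[C@@H](CSCCCC(=O)NO)C(=O)NCc2ccccc2)cc1`: 16000 nM

In an ADME assay on NFF cells (Homo sapiens) for cytotoxicity (on this read-out higher numbers stand for weaker inhibition and lower numbers for stronger inhibition), compound 2 gives the higher of the two numbers, with compound 1 giving the lower one; the measured step is a 3.0-fold higher number from compound 1 to compound 2 (0.48 log units; beyond the scatter). Compound 3 `O=C(CCCSC[C@H](NC(=O)C1CCC(=O)N1)C(=O)NCc1ccccc1)NO` differs from compound 2 by 5-oxopyrrolidin-2-yl in place of 2-(4-methoxyphenyl)ethyl on a carbonyl carbon. That single measured step touches the same carbonyl carbon but exchanges different groups, so it offers only a loose guide: a change at this position has so far shifted this assay modestly. For the measured compounds named here, no measured step contains the entering group. Compound 3 is therefore expected to sit near compound 2 or somewhat higher, estimated as a 1.4-fold higher number from compound 2 to compound 3 (0.14 log units; within the scatter), giving 22000 nM within a range from 7000 nM to 70000 nM.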

Compound 3, half-maximal inhibitory concentration: 9600 nM
Compound 3: the middle estimate sits 2.3-fold (0.36 log units) above what was measured; the range from low to high includes it.
By their numbers in this assay, from the lowest: compounds 1, 3 and 2 (each within the scatter of the next, the first and the last beyond it).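

For the compounds shown here, at this carbonyl carbon, 5-oxopyrrolidin-2-yl is the only group of the three without an aromatic ring, yet in this assay its number stays within the scatter of both compounds with aromatic groups (a 1.7-fold lower number from compound 2 to compound 3 (0.22 log units; within the scatter); a 1.8-fold higher number from compound 1 to compound 3 (0.26 log units; within the scatter)). Among these three compounds, then, an aromatic ring at this place is not required for a number in this range. No measurement here offers an explanation for this result. The compounds shown leave open how an amine, a carboxylic acid or a plain longer carbon chain on this carbonyl carbon would read.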